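Methyl on the amide nitrogen of a bile acid receptor agonist

The source may report more compounds than this note shows. Statements on the series, on what has been measured and on what is new or still open speak of the compounds shown alone.

Measured compounds:
Compound 1, `CC(C)c1onc(-c2c(Cl)cccc2Cl)c1COc1ccc(/C=C/c2cccc(C(=O)N(Cc3ccccc3)Cc3ccccc3)c2)c(Cl)c1`: 35100 nM
Compound 2, `CC(C)c1onc(-c2c(Cl)cccc2Cl)c1COc1ccc(C(=O)Nc2cccc(C(=O)O)c2)c(Cl)c1`: 3000 nM

Of the compounds shown here, two sharing the same core have been tested in a functional assay on HEK293 cells for agonist activity at Bile acid receptor (Homo sapiens); a higher number here means that more compound is needed for the effect, a lower number that less compound is needed. Compound 1, `CC(C)c1onc(-c2c(Cl)cccc2Cl)c1COc1ccc(/C=C/c2cccc(C(=O)N(Cc3ccccc3)Cc3ccccc3)c2)c(Cl)c1`, gives 35100 nM in this assay. Compound 2, `CC(C)c1onc(-c2c(Cl)cccc2Cl)c1COc1ccc(C(=O)Nc2cccc(C(=O)O)c2)c(Cl)c1`, gives 3000 nM in this assay, which is the lower of the two numbers, and the gap between compound 1 and compound 2 lies beyond the usual scatter. Among the measured compounds shown here, no step between two measured compounds that differ in a single place is available, so no measured step guides the next change.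

Compound 3, `CC(C)c1onc(-c2c(Cl)cccc2Cl)c1COc1ccc(C(=O)N(C)c2cccc(C(=O)O)c2)c(Cl)c1`, is the next compound to be measured in this assay. It differs from compound 2 by methyl in place of hydrogen on an amide-type nitrogen. The account of what this kind of change does is empty here, so the expectation rests on compound 2 alone. A small step from compound 2 to compound 3 is expected, a 1.7-fold higher number from compound 2 to compound 3 (0.22 log units; within the scatter), toward a somewhat higher number but possibly within the scatter. For compound 3 the estimated value in this assay is 5000 nM, with a range from 1500 nM to 20000 nM.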

Compound 3, half-maximal effective concentration: 3100 nM
Compound 3: middle estimate off by 1.6-fold (0.21 log units), on the high side; low and high end bracket the measured number.
By their numbers in this assay, from the lowest: compounds 2 and 3 (each within the scatter of the next); then compound 1.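

In this assay, methyl in place of hydrogen on the amide-type nitrogen, whose other neighbours are an aromatic carbon and the carbonyl carbon, gives a 1.0-fold higher number from compound 2 to compound 3 (0.01 log units; within the scatter). Among the compounds shown here, this is the first comparison in the set between compounds that differ in one place, and it shows that, with the rest of the structure held as in compound 2, the amide hydrogen is not needed for a value of this size in this assay. No measurement here explains why the two numbers lie so close together.

Going by these compounds, whether a larger group on the same nitrogen, such as ethyl or benzyl, would also leave the number within the scatter remains open, as does the effect of replacing the carboxylic acid of the (3-carboxyphenyl)amino group with a methyl ester or a primary amide. Compound 1 differs from compound 2 in more than one place, so the gap between their values cannot be assigned to any single part of the structure, and the result for methyl on this nitrogen says nothing about the other parts.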